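Cyano for Methyl on a Shared Core

The source may hold more compounds than are shown below. What is called first, only, known or untested is meant among the compounds shown, and "the series" means these compounds.

Compound 2 `Cc1cnn(C(=O)N2CCN(C(c3ccc(OCc4ccccc4)cc3)c3ccc(OCc4ccccc4)cc3)CC2)c1` was tested in an assay on membranes from brain for binding affinity to Fatty-acid amide hydrolase 1 (Mus musculus), read by fluorescence, with stated times of 1 h and 30 min; a higher number here means a weaker inhibitor, a lower number a stronger inhibitor. In this assay compound 2 gives > 100000 nM, which is a limit of the measurement rather than a number. Compound 1 `N#Cc1cnn(C(=O)NCc2ccc(OC(c3ccccc3)c3ccccc3)cc2)c1` carries a different side chain and already bears the cyano group. In this assay compound 1 gives > 100000 nM, also a limit and not a number. Within the data shown here, both values sit at the same point, as the limit of > 100000 nM in this assay, at which 2 of the 2 values shown sit, records, so no measured step exists to lean on. Compound 3 `N#Cc1cnn(C(=O)N2CCN(C(c3ccc(OCc4ccccc4)cc3)c3ccc(OCc4ccccc4)cc3)CC2)c1` keeps the whole of compound 2 except for one change: cyano in place of methyl on an aromatic carbon. Without any measured step between these two structures, the expected step from compound 2 to compound 3 in this assay is a number no higher from compound 2 to compound 3 (the limit leaves the size open), meaning no change beyond the usual scatter. Compound 3 is therefore expected to give about 100000 nM, within a range from 30000 nM to 300000 nM, and most likely only another limit.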

Compound 3, half-maximal inhibitory concentration: 790000 nM
Compound 3: middle estimate off by 7.9-fold (0.90 log units), on the low side, outside the stated range (above it).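

The step from compound 2 to compound 3 cannot be read in this assay, as compound 2 has only a limit and not a number: the limit of > 100000 nM in this assay, at which 2 of the 3 values shown sit.

The compounds shown leave open whether cyano in place of methyl on this shared core changes inhibition at all, and by how much.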